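This account rests on a few compounds, and the source may have more. Where it says the series, first, only, none or still open, it means among the compounds named here.

Of the compounds shown here, three have been measured in a functional assay on the whole organism for inhibition, with Digitaria ciliaris as the target, with a stated time of 72 h, tested at 10 mg/L; a lower number here means less inhibition of growth, a higher number more inhibition of growth at the concentration tested. Compound 1, `COc1cc(C)nc2n/c(=N/C(=O)c3c(-c4ccc(Cl)cc4Cl)noc3C)sn12`, gives 50.3%. Compound 2, `COc1cc(SC)nc(NC(=S)NC(=O)c2c(-c3ccc(Cl)cc3Cl)noc2C)n1`, gives 34.8%. Compound 3, `Cc1onc(-c2ccc(Cl)cc2Cl)c1C(=O)/N=c1/nc2nc(Cl)cc(C)n2s1`, gives 32.8%, the lowest of the three numbers; its gap to compound 2 lies within the usual scatter, while its gap to compound 1 lies beyond it. Compound 4, `COc1cc(Cl)nc2n/c(=N/C(=O)c3c(-c4ccc(Cl)cc4Cl)noc3C)sn12`, has not yet been measured. It differs from compound 3 in one place: methoxy in place of methyl on an aromatic carbon. Among the compounds with values here, no pair of measured compounds differs by just this change, so there is no measured step to lean on. Compound 1 also carries a methoxy and gives the highest number, but it differs from compound 4 in more than one place, so only a loose hint is available. The step from compound 3 to compound 4 in this assay is expected to be small, leaning upward but possibly not beyond the scatter, as a number 7.2 percentage points higher from compound 3 to compound 4 (within the scatter). Compound 4 is thus estimated to give 40%, within a range from 22% to 58%.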

Compound 4, percent growth inhibition at one concentration: 16.5%
Beside the measured number, compound 4's estimate is 23.5 percentage points above it; measured number outside the range, below it.
By their numbers in this assay, from the lowest: compound 4; then compounds 3 and 2 (each within the scatter of the next); then compound 1.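

In this assay, methoxy in place of methyl on this aromatic carbon gives a number 16.3 percentage points lower from compound 3 to compound 4 (beyond the scatter) and so shows that the position responds to this change, with the number falling rather than rising. With the methoxy kept, chloro in place of methyl on an aromatic carbon gives a number 33.8 percentage points lower from compound 1 to compound 4 (beyond the scatter) as a second drop, so both steps that take a methyl off this six-membered ring lower growth inhibition, a pattern that rests on these two steps alone. Nothing measured here explains why either drop occurs.

From the compounds shown here alone, it remains open whether the fall comes from gaining the methoxy or from losing the methyl, and whether it would persist without the chloro group on the same ring. An ethoxy group, an amine or a longer chain on this carbon could help separate these possibilities.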